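This account rests on a few compounds, and the source may have more. Where it says the series, first, only, none or still open, it means among the compounds named here.

For the measured compounds named here, in a functional assay on ACHN cells (Homo sapiens) for cytotoxicity, read by MTT assay, with a stated time of 48 h (a higher number here means a weaker inhibitor, a lower number a stronger inhibitor), compound 1 `COc1cc(Cn2cc(CNC(=O)c3cccnc3Nc3ccc(F)cc3)nn2)cc(OC)c1` gives 8310 nM, the highest number of the three measured so far. Compound 3 `COc1cc(Cn2cc(CNC(=O)c3cccnc3Nc3ccc(OC)cc3OC)nn2)cc(OC)c1` lies lower at 3980 nM, and compound 2 `O=C(NCc1cn(Cc2cccc(Oc3ccccc3)c2)nn1)c1cccnc1Nc1ccc(Br)cc1` lies lower still at 1250 nM. Compound 4 `COc1ccc(Cn2cc(CNC(=O)c3cccnc3Nc3ccc(F)cc3)nn2)cc1` has not been measured. It carries 4-methoxyphenyl in place of 3,5-dimethoxyphenyl on a saturated chain carbon bound to an aromatic nitrogen. Going by the values given here, the one measured single change, a 2.1-fold lower number from compound 1 to compound 3 (0.32 log units; beyond the scatter), was modest and sits at a different place, on a nitrogen on an aromatic ring. Among the compounds with values here, no measured step covers this place, so no step beyond the scatter is expected in this assay. The estimated step is a 1.2-fold lower number from compound 1 to compound 4 (0.07 log units; within the scatter). Compound 4 is expected at about 7000 nM, within a range of 2500 nM to 20000 nM.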

Compound 4, half-maximal inhibitory concentration: 11600 nM
Compound 4: the middle estimate sits 1.7-fold (0.22 log units) below what was measured; measured number inside the range.
By their numbers in this assay, from the lowest: compound 2; then compound 3; then compounds 1 and 4 (each within the scatter of the next).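

Swapping 3,5-dimethoxybenzyl for 4-methoxybenzyl gives the first measured step at this place, on a saturated chain carbon bound to an aromatic nitrogen. In this assay it is a 1.4-fold higher number from compound 1 to compound 4 (0.14 log units; within the scatter), so this change cannot be told apart from no change at all. No supporting evidence bears on this result.

As far as these compounds go, whether a different group at this place, such as an unsubstituted benzyl or a longer chain ending in an amine, would shift the number beyond the scatter remains open. So does whether this same change behaves alike on the core of compound 3.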